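This account rests on a few compounds, and the source may have more. Where it says the series, first, only, none or still open, it means among the compounds named here.

Measured so far:
compound 1, `COc1ccc(F)cc1CNCCCNc1ccnc2cc(C3CCCCC3)ccc12`: 23 10^-6 cm/s
compound 2, `Fc1ccc(-c2ccc3c(NCCCNCc4ccco4)ccnc3c2)cc1`: 237 10^-6 cm/s

Of the two compounds measured in an ADME assay for permeability, using PAMPA, with a stated time of 30 min, at pH 7.4 (a lower number here means that the compound crosses the layer more slowly, a higher number that the compound crosses the layer faster), compound 1 stands lowest; compound 2 crosses the layer faster, and that gap lies beyond the usual scatter of repeat measurements. Going by the values given here, no pair of measured compounds differs in just one place, so no step can be read from the data themselves.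

Compound 3, `COc1ccc(F)cc1CNCCCNc1ccnc2cc(CCc3ccccc3)ccc12`, differs from compound 1 in one place: phenethyl in place of cyclohexyl on an aromatic carbon. A small rise in this assay seems likely, though it could well fall inside the scatter; the expected step is a 1.7-fold higher number from compound 1 to compound 3 (0.24 log units; within the scatter). For compound 3 the estimate is 40 10^-6 cm/s, in a range from 15 10^-6 cm/s to 120 10^-6 cm/s.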

Compound 3, apparent permeability: 23 10^-6 cm/s
Beside the measured number, compound 3's estimate is 1.7-fold (0.24 log units) above it; low and high end bracket the measured number.
By their numbers in this assay, from the lowest: compounds 1 and 3 (each within the scatter of the next); then compound 2.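

At this aromatic carbon, phenethyl in place of cyclohexyl gives, in this assay, no change at the digits printed from compound 1 to compound 3 (within the scatter). Going by these compounds alone, this is the first step that can be read at a single place: here, a group with more heavy atoms and an aromatic ring in place of a non-aromatic one leaves the number within the scatter. Nothing measured here explains this result. Still open, going by these compounds, is whether a group of another kind at this carbon, such as an amine or a carboxylic acid, would also leave the number within the scatter.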